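Sulfonamide nitrogen substituent swap: cyclobutyl to isobutyl

This account rests on a few compounds, and the source may have more. Where it says the series, first, only, none or still open, it means among the compounds named here.

Measured compounds:
compound 1, `CC(C)CN(c1ccc(N(C)C)cc1)S(=O)(=O)c1ccc2c(c1)C(O)CC(C1CCOCC1)O2`, 3.51
compound 2, `CC(C)CN(c1ccc(F)cc1)S(=O)(=O)c1ccc2c(c1)C(O)CC(C1CCOCC1)O2`, 3.39
compound 3, `Cc1ccc(N(C2CCC2)S(=O)(=O)c2ccc3c(c2)C(O)CC(C2CCOCC2)O3)c(C)c1`, 3.77

In a physicochemical assay for lipophilicity, at pH 7.4 (on this read-out lower numbers stand for lower lipophilicity and higher numbers for higher lipophilicity), compound 3 gives the highest of the three numbers; compound 1 sits within the scatter of it, while compound 2 lies beyond the scatter below it. Going by the values given here, the one measured step, a number 0.12 log units lower from compound 1 to compound 2 (within the scatter), concerns a change on the aromatic ring and is within the scatter; it does not touch the sulfonamide nitrogen.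

Compound 4, `Cc1ccc(N(CC(C)C)S(=O)(=O)c2ccc3c(c2)C(O)CC(C2CCOCC2)O3)c(C)c1`, differs from compound 3 in one place: isobutyl in place of cyclobutyl on a sulfonamide nitrogen. Among the compounds with values here, no measured pair shows this change, so no step bears on it; the expectation rests only on compound 3 and 3.77 as the starting point. A step of at most modest size is expected, a number 0.13 log units higher from compound 3 to compound 4 (within the scatter), and it may well stay within the scatter.

Compound 4 is therefore estimated to give 3.9, with a range from 3.5 to 4.3.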

Compound 4, distribution coefficient: 4.19
Estimate against measurement, compound 4: 0.29 log units below; low and high end bracket the measured number.
By their numbers in this assay, from the lowest: compounds 2, 1 and 3 (each within the scatter of the next, the first and the last beyond it); then compound 4.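

In this assay, isobutyl in place of cyclobutyl on a sulfonamide nitrogen gives a number 0.42 log units higher from compound 3 to compound 4 (beyond the scatter), so at this position removing the ring registers even though the heavy-atom count stays the same. With isobutyl on that nitrogen, the aryl group also matters: 2,4-dimethylphenyl in place of 4-fluorophenyl gives a number 0.80 log units higher from compound 2 to compound 4 (beyond the scatter), and 2,4-dimethylphenyl in place of 4-(dimethylamino)phenyl gives a number 0.68 log units higher from compound 1 to compound 4 (beyond the scatter), whereas the earlier step between the two other aryl groups, a number 0.12 log units lower from compound 1 to compound 2 (within the scatter), showed no such separation. No measurement at hand accounts for these shifts.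

From the compounds shown here alone, whether the cyclobutyl-to-isobutyl step recurs with 4-fluorophenyl or 4-(dimethylamino)phenyl on the nitrogen remains open. Also open, going by these compounds, is where a cyclopentyl ring or a longer chain such as n-hexyl at this position would fall.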